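This account rests on a few compounds, and the source may have more. Where it says the series, first, only, none or still open, it means among the compounds named here.

Of the compounds shown here, three have so far been measured in a functional assay on HEK293 cells for antagonist activity at transient receptor potential cation channel subfamily V member 1 (Rattus norvegicus), read by calcium flux; on this read-out lower numbers stand for stronger inhibition and higher numbers for weaker inhibition. Compound 1 `FC(F)(F)c1ccc(Nc2ncnc3c2CCN(c2ncccc2C(F)(F)F)C3)cc1` gives 71 nM. Compound 2 `Cc1ccc(Nc2ncnc3sc(Nc4c(Cl)cccc4Cl)nc23)cc1` gives 32 nM, and compound 3 `CSc1ccc(Nc2ncnc3sc(Nc4c(Cl)cccc4Cl)nc23)cc1` gives 12 nM, the lowest of the three numbers, with compound 2 nearest to it and compound 1 furthest away. For the measured compounds named here, the one step between compounds differing in a single place, a 2.7-fold lower number from compound 2 to compound 3 (0.43 log units; beyond the scatter), shows that exchanging the group on this aromatic carbon can shift the number beyond the scatter. Compound 4 `O=C(c1ccc(Nc2ncnc3sc(Nc4c(Cl)cccc4Cl)nc23)cc1)N1CCCC1` differs from compound 3 by (pyrrolidin-1-yl)carbonyl in place of methylsulfanyl on an aromatic carbon. Going by the values given here, no measured compound carries a carbonyl at that place, so the earlier step bears on compound 4 only by marking the position as responsive. Compound 4 is therefore expected to give 40 nM, within 8 nM to 200 nM, an expected step of a 3.3-fold higher number from compound 3 to compound 4 (0.52 log units; beyond the scatter) toward weaker inhibition.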

Compound 4, half-maximal inhibitory concentration: > 5000 nM
Compound 4 gave a limit, no number; the forecaster's own chance of this, stated with the estimate: 5%; middle value at least 120-fold (2.09 log units) from the limit.
By their numbers in this assay, from the lowest: compound 3; then compound 2; then compound 1. At a limit, above all of these: compound 4.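

In this assay compound 4 reaches only a limit of the assay, not a number: the limit of > 5000 nM in this assay, at which 1 of the 4 values shown sits. Placing (pyrrolidin-1-yl)carbonyl on this aromatic carbon gives an at least 410-fold higher number from compound 3 to compound 4 (2.61 log units; beyond the scatter) and an at least 150-fold higher number from compound 2 to compound 4 (2.19 log units; beyond the scatter), both large, whereas the exchange between methyl and methylsulfanyl there was modest. The position is therefore not merely responsive: a single change at it can carry inhibition out of the measurable range.

Going by these compounds, it remains open whether the loss follows the carbonyl or the pyrrolidine ring. A primary amide, a methyl ketone or a methyl ester at this place would separate the two.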